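This account rests on a few compounds, and the source may have more. Where it says the series, first, only, none or still open, it means among the compounds named here.

Compound 2 `Cc1ccc(-n2[nH]c(C)c(/N=N/c3c(O)cc(S(=O)(=O)O)c4ccccc34)c2=O)cc1C` is one of two measured compounds that share the same core and differ only in the aromatic group carried on one ring nitrogen. In an assay on BaF3 cells with thrombopoietin receptor (Homo sapiens) as the target, read by a luciferase reporter (a higher number here means that more compound is needed for the effect, a lower number that less compound is needed), compound 2 gives 40 nM. Going by the values given here, its only measured neighbour is compound 1 `Cc1[nH]n(-c2cccc(C(F)(F)F)c2)c(=O)c1/N=N/c1c(O)cc(S(=O)(=O)O)c2ccccc12`, which in this assay gives 40 nM, so the two stand level, and the step of no change at the digits printed from compound 1 to compound 2 (within the scatter) is within the scatter.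

The unmeasured compound 3 `Cc1[nH]n(-c2ccc(C(C)(C)C)cc2)c(=O)c1/N=N/c1c(O)cc(S(=O)(=O)O)c2ccccc12` changes that same aromatic group once more: 4-(tert-butyl)phenyl in place of 3,4-dimethylphenyl on an aromatic nitrogen. Among the compounds with values here, the one measured step that bears on this position, from compound 1 to compound 2, exchanged one substituted phenyl group for another and left the read-out unchanged. Nothing else measured here speaks to a tert-butyl group on this ring, so the expectation rests on that single step alone.

Compound 3 is therefore expected to give about 40 nM in this assay, with a range from 15 nM to 120 nM. The step that this estimate implies, no change at the digits printed from compound 2 to compound 3 (within the scatter), is expected to stay within the scatter, with no clear direction.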

Compound 3, half-maximal effective concentration: 20 nM
Compound 3: the middle estimate sits 2.0-fold (0.30 log units) above what was measured; the range from low to high includes it.
By their numbers in this assay, from the lowest: compounds 3, 1 and 2 (each within the scatter of the next).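

In this assay, the exchange of the aromatic group on the ring nitrogen gives a 2.0-fold lower number from compound 2 to compound 3 (0.30 log units; within the scatter), and the comparison with the first compound gives a 2.0-fold lower number from compound 1 to compound 3 (0.30 log units; within the scatter), so both steps stay within the scatter. The earlier pair compared only 3-(trifluoromethyl)phenyl with 3,4-dimethylphenyl, whereas this result adds 4-(tert-butyl)phenyl, which has 10 heavy atoms against 8 for 3,4-dimethylphenyl, and shows that this larger all-carbon group also leaves the read-out within the scatter of the other two. Nothing available here explains why these three groups read alike.

The compounds shown leave open whether this holds beyond phenyl rings carrying such groups, for example for a phenyl ring bearing a carboxylic acid or an amine, or for a longer alkyl chain on the nitrogen in place of the ring. They also leave open whether the same freedom survives when the shared core changes, such as when the methyl group on the five-membered ring gives way to an ethyl group.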